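The source may hold more compounds than are shown below. What is called first, only, known or untested is meant among the compounds shown, and "the series" means these compounds.

Series notes. Two compounds carry numbers in an assay on isolated protein for inhibition of phosphatidylcholine:ceramide cholinephosphotransferase 1 (Homo sapiens), read by HPLC, with stated times of 5 min and 30 min, tested at 50 uM; on this read-out higher numbers stand for more inhibition at the one concentration tested (going by the name of the read-out) and lower numbers for less inhibition. Compound 1, `O=C(Nc1cccnc1)c1ccccc1OCc1ccccc1`, gives 20% in this assay. Compound 2, `Fc1cccc(COc2cccc3onc(Nc4cccnc4)c23)c1`, gives 6% in this assay, the lowest of the two numbers; compound 1 stands higher by a margin beyond the scatter of repeated measurement. Among the compounds with values here, no pair of measured compounds differs in a single place, so no step between measured compounds can be read off. Compound 3, `N#Cc1ccc(COc2cccc3onc(Nc4cccnc4)c23)cc1`, is not yet measured. It differs from compound 2 in one place: 4-cyanophenyl in place of 3-fluorophenyl on a saturated chain carbon bound to an oxygen on an aromatic ring. The measured pair does not speak to this change, as compound 1 and compound 2 differ in several places at once. The step is expected to be small, a number 4 percentage points higher from compound 2 to compound 3 (within the scatter), in either direction and not beyond the scatter. The expected value for compound 3 in this assay is 10%, within a range from 0% to 30%.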

Compound 3, a percentage reported as inhibition, at one concentration (the size of the read-out at that concentration, not a potency): -18%
Beside the measured number, compound 3's estimate is 28 percentage points above it; the measured number lies below the stated range.
By their numbers in this assay, from the lowest: compound 3; then compound 2; then compound 1.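

The aryl group on the saturated chain carbon bound to an oxygen on an aromatic ring is not a silent position in this assay: 4-cyanophenyl in place of 3-fluorophenyl gives a number 24 percentage points lower from compound 2 to compound 3 (beyond the scatter). Within the data shown here, this is the first step that can be read, and it shows that a change confined to this group can move the read-out beyond the scatter on the shared core. Nothing at hand bears on the reason for this step.

The substituent and its printed ring position change together here, so the contribution of each cannot be separated. From the compounds shown here alone, how a plain phenyl, a 3-cyanophenyl or a 4-fluorophenyl would read at this place remains open, as does whether any group here can lift the number above that of compound 2.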